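Working notes: acid dissociation across four related compounds

The source may report more compounds than this note shows. Statements on the series, on what has been measured and on what is new or still open speak of the compounds shown alone.

Compound 1 `COc1ccc(F)cc1CNCCCNc1ccnc2cc(Oc3ccc(F)cc3)ccc12`, compound 2 `COc1ccc(F)cc1CNCCCNc1ccnc2cc(Oc3cccc(N(C)C)c3)ccc12` and compound 3 `COc1cccc(CNCCCNc2ccnc3cc(Oc4cccc(N(C)C)c4)ccc23)c1O` have been measured in a physicochemical assay for acid dissociation; compound 4 `COc1cccc(CNCCCNc2ccnc3cc(Oc4ccc(F)cc4)ccc23)c1O` has not. In this assay compound 1 gives 9.28, compound 2 gives 9.28 and compound 3 gives 9.28. The step of no change at the digits printed from compound 2 to compound 1 (within the scatter) belongs to the change (4-fluorophenyl in place of 3-(dimethylamino)phenyl on an oxygen on an aromatic ring). The step of no change at the digits printed from compound 2 to compound 3 (within the scatter) belongs to 2-hydroxy-3-methoxyphenyl in place of 5-fluoro-2-methoxyphenyl on a saturated chain carbon bound to an amine nitrogen, which is how the core of compound 3 differs from the core of compound 2. Compound 4 arises from compound 3 by 4-fluorophenyl in place of 3-(dimethylamino)phenyl on an oxygen on an aromatic ring, the same change as from compound 2 to compound 1, at the same place. Because no change at the digits printed from compound 2 to compound 1 (within the scatter) stayed within the scatter, the step of no change at the digits printed from compound 3 to compound 4 (within the scatter) is expected to be of the same size. Compound 4 is therefore estimated at 9.28, with 9 and 9.6 as the expected range.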

Compound 4, acid dissociation constant: 9.28
Compound 4: middle estimate and measured number agree at the digits printed; the range from low to high includes it.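

In this assay the change from 3-(dimethylamino)phenoxy to 4-fluorophenoxy gives no change at the digits printed from compound 3 to compound 4 (within the scatter) on the core of compound 3, matching no change at the digits printed from compound 2 to compound 1 (within the scatter) on the core of compound 2, and the change of core with 4-fluorophenoxy in place gives no change at the digits printed from compound 1 to compound 4 (within the scatter) as well. This shows that a step within the scatter stayed within the scatter on these two cores, but it does not show that a step of real size would carry from one core to another. Nothing available explains why the values stay level.

Going by these compounds, whether a longer chain on the amine nitrogen would shift the read-out in this assay remains open. So does the effect of a carboxylic acid or a further amine on the aromatic ring on the oxygen.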